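The source may hold more compounds than are shown below. What is called first, only, known or untested is meant among the compounds shown, and "the series" means these compounds.

Working notes on the series, read in a functional assay on MCF7 cells (Homo sapiens) for inhibition, read by trypan blue exclusion, with a stated time of 72 h; on this read-out higher numbers stand for weaker inhibition of growth and lower numbers for stronger inhibition of growth. Compound 1 `CC/C(=C(/c1ccc(NC(=O)C(C)C)cc1)c1ccc(OC)cc1)c1ccccc1` gives > 30000 nM, which is a limit of the assay and not a number. Among the measured compounds shown here, compound 2 `CC/C(=C(/c1ccc(NC(=O)C(C)C)cc1)c1ccc(OC)cc1)c1ccc(Cl)cc1Cl` gives 6600 nM and holds one of only two numbers so far. The other belongs to compound 3 `CC/C(=C(\c1ccc(NC(=O)C(C)C)cc1)c1ccc(OC)cc1)c1ccc(Cl)cc1Cl`, at 13200 nM, which has the same atoms and bonds as compound 2. The step of a 2.0-fold higher number from compound 2 to compound 3 (0.30 log units; within the scatter) separates that pair, so the double-bond configuration shows no effect that can be told from scatter. The larger step is an at least 4.5-fold lower number from compound 1 to compound 2 (0.65 log units; beyond the scatter), and it lies on the 2,4-dichlorophenyl side.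

Compound 4 `CC/C(=C(\c1ccc(O)cc1)c1ccc(NC(=O)C(C)C)cc1)c1ccc(Cl)cc1Cl` differs from compound 2 by hydrogen in place of methyl on an oxygen on an aromatic ring, which turns methoxy into hydroxy, with hydrogen in place of methyl on an oxygen on an aromatic ring. For the measured compounds named here, no measured step touches this place, so neither measured step gives a direction. The step of an at least 4.5-fold lower number from compound 1 to compound 2 (0.65 log units; beyond the scatter) serves only as a rough upper guide to size, and a small change is expected in this assay, perhaps towards a lower number. The expected change is a 1.5-fold lower number from compound 2 to compound 4 (0.17 log units; within the scatter). Compound 4 is estimated at 4500 nM, with an expected range of 1500 nM to 13000 nM.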

Compound 4, concentration for 50% growth inhibition: 12500 nM
Compound 4: middle estimate off by 2.8-fold (0.44 log units), on the low side; the range from low to high includes it.
By their numbers in this assay, from the lowest: compounds 2, 4 and 3 (each within the scatter of the next). At a limit, above all of these: compound 1.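

Among the compounds shown here, this is the first measured step at the oxygen on the aromatic ring, as earlier steps touched only the 2,4-dichlorophenyl side and the double-bond configuration. In this assay, methoxy to hydroxy gives a 1.9-fold higher number from compound 2 to compound 4 (0.28 log units; within the scatter), so compounds 2 and 4 cannot be told apart at this position, and the free hydroxy and the methyl ether read alike with 2,4-dichlorophenyl on the chain. Nothing on hand bears on the reason for this step.

The compounds shown leave open whether the same exchange reads alike with phenyl in place of 2,4-dichlorophenyl, where the assay gave only a limit. They also leave open how this position reads with a longer chain on the oxygen, such as ethoxy, or with an amine or a carboxylic acid in place of the hydroxy.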